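A few compounds are considered here, and "the series" means these few. Any claim that something is new, unique, unknown or untested is made for them only; others in the source may bear on it.

Measured compounds in a functional assay on NCI-H460 cells (Homo sapiens) for antiproliferative activity, with a stated time of 72 h; on this read-out lower numbers stand for stronger inhibition and higher numbers for weaker inhibition:
- compound 1 `C=CC[C@H]1C[C@]2([C@@H](C)Cc3ccc(OC)c(OC)c3)OCOC2=CC1=O` gives 260 nM
- compound 2 `C=CC[C@H]1C[C@]2([C@H](C)Cc3ccc(OC)c(OC)c3)OCOC2=CC1=O` gives 320 nM
- compound 3 `C=CC[C@@H]1C[C@]2([C@H](C)Cc3ccc(OC)c(OC)c3)OCOC2=CC1=O` gives only a limit, > 4000 nM

Compound 2 holds the higher of the two numbers shown, but its gap to compound 1 is small: a 1.2-fold higher number from compound 1 to compound 2 (0.09 log units; within the scatter). The third value is a limit of this assay and not a number (the limit of > 4000 nM in this assay, at which 1 of the 3 values shown sits). The steps among the three measured compounds are all changes of configuration alone the fact that compounds 1 and 2 differ only in the configuration as drawn the fact that compounds 1 and 3 differ only in the configuration as drawn (the fact that compounds 2 and 3 differ only in the configuration as drawn); the one at the saturated ring carbon is large, an at least 12-fold higher number from compound 2 to compound 3 (1.09 log units; beyond the scatter), while the one at the saturated chain carbon stays within the scatter.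

Compound 4 `C=CC[C@H]1C[C@]2(CCc3ccc(OC)c(OC)c3)OCOC2=CC1=O` differs from compound 2 by hydrogen in place of methyl on a saturated chain carbon bound to a saturated chain carbon and a saturated ring carbon. Among the compounds with values here, no measured step removes a group, so none bears on it directly; the closest is the within-scatter step at that same chain carbon, a 1.2-fold higher number from compound 1 to compound 2 (0.09 log units; within the scatter). A modest step is therefore expected, most likely towards a higher number, estimated as a 1.7-fold higher number from compound 2 to compound 4 (0.24 log units; within the scatter). Compound 4 is expected to give about 550 nM in this assay, within 200 nM to 1600 nM.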

Compound 4, half-maximal inhibitory concentration: 3200 nM
The estimate for compound 4 lay 5.8-fold (0.76 log units) below the measured number; the measured number lies above the stated range.
By their numbers in this assay, from the lowest: compounds 1 and 2 (each within the scatter of the next); then compound 4. At a limit, above all of these: compound 3.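

In this assay, the methyl on this saturated chain carbon matters even though its configuration as drawn did not: replacing it with hydrogen gives a 10-fold higher number from compound 2 to compound 4 (1.00 log units; beyond the scatter), and likewise a 12-fold higher number from compound 1 to compound 4 (1.09 log units; beyond the scatter), both beyond the scatter. Compounds 1 and 2 carry the methyl in the two drawn configurations and lie within the scatter of each other, so what the new result adds is that having a methyl at this place counts, whichever way it is drawn. Nothing given here explains why this one small change has so large an effect.

On these data alone, whether an ethyl group, a hydroxyl group or an amine at this same carbon would keep the number as low as the methyl does remains open. Also open, as far as these compounds go, is whether the same step would appear on cell lines other than this one.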